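Cyclohexyl for tert-butoxy on the carbonyl carbon

A few compounds are considered here, and "the series" means these few. Any claim that something is new, unique, unknown or untested is made for them only; others in the source may bear on it.

Compound 1 `CC(=O)N[C@@H]1CCN(c2cc(C)nn3c(-c4ccc(OC(F)(F)F)cc4)c(C)nc23)C1`: > 95%
Compound 2 `COc1ccc(-c2c(C)nc3c(N4CCN(C(=O)OC(C)(C)C)CC4)cc(C)nn23)cc1OC`: > 95%

In an ADME assay on microsomes from liver (Mus musculus) for metabolic stability, read by LC-MS, with NADPH named in the record, with a stated time of 60 min, tested at 1 uM, in the absence of a further agent (a lower number here means that less of the compound is left, a higher number that more of the compound is left), compound 2 gives > 95%, which is a limit and not a number. Among the measured compounds shown here, the series so far offers only (the limit of > 95% in this assay, at which 2 of the 2 values shown sit), so no measured step is available as a guide. Compound 3 `COc1ccc(-c2c(C)nc3c(N4CCN(C(=O)C5CCCCC5)CC4)cc(C)nn23)cc1OC` carries cyclohexyl in place of tert-butoxy on a carbonyl carbon. A modest fall, perhaps none beyond the scatter, is expected because compound 2 stands at > 95% and only a downward move could be read. The expected change is a number at least 13 percentage points lower from compound 2 to compound 3 (beyond the scatter) in this direction. For compound 3 82% is the estimated value, with 55% to 98% as the expected range.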

Compound 3, percent of the compound remaining: > 95%
Compound 3 gave a limit, no number; the forecaster's own chance of this, stated with the estimate: 40%; middle value at least 13 percentage points away from the limit.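

Compound 2 and compound 3 both give limits rather than numbers in this assay, so no step can be read between them. The compounds shown leave open whether cyclohexyl in place of tert-butoxy changes the percent remaining, with every value at one limit: the limit of > 95% in this assay, at which 3 of the 3 values shown sit.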